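Chalcone series: ring substitution and the Caco-2 read-out

The compounds below may be only part of what the source reports. "The series", "measured", "known", "first", "only" and "open" are said of these compounds alone.

Measured so far:
compound 1 `COc1cc(O)c(C(=O)/C=C/c2ccc(F)cc2)c(OC)c1` gives 30%
compound 2 `COc1cc(OC)c(C(=O)/C=C/c2ccccc2)c(OC)c1` gives 24%
compound 3 `COc1cc(O)c(C(=O)/C=C/c2ccccc2OC)c(OC)c1` gives 37%

The three values come from a functional assay on Caco-2 cells (Homo sapiens), read by fluorescence and BrdU incorporation, with a stated time of 48 h, tested at 25 uM; a lower number here means a stronger effect, a higher number a weaker effect of the compound at the concentration tested. Compound 2 stands lowest of the three numbers. Its nearest neighbour is compound 1, whose number lies within the usual scatter of that of compound 2, so the two cannot be ordered. Compound 3 lies furthest from compound 2, with a gap beyond the scatter; compound 3 is the weaker of the two in this assay. Compound 1 and compound 3 differ in more than one place, and their values are simply noted side by side.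

The next compound, compound 4 `COc1cc(OC)c(C(=O)/C=C/c2ccc(F)cc2)c(OC)c1`, has not yet been measured in this assay. It differs from compound 2 in one place: fluoro in place of hydrogen on an aromatic carbon.

Among the compounds with values here, no single-place pair among the measured compounds shows the effect of this change. Compound 1, which carries the same fluoro group on a different core, gives 30% in this assay, a number within the scatter of compound 2. On that basis the expected step of a number 2 percentage points higher from compound 2 to compound 4 (within the scatter) is small, in no clear direction, and not beyond the scatter. For compound 4 the estimate in this assay is 26%, with a range from 14% to 38%.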

Compound 4, a percentage reported as activity, at one concentration (the size of the read-out at that concentration, not a potency): 13%
Compound 4: middle estimate off by 13 percentage points, on the high side; measured number below the stated range.
By their numbers in this assay, from the lowest: compound 4; then compounds 2, 1 and 3 (each within the scatter of the next, the first and the last beyond it).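

Within the data shown here, on the shared core, phenyl to 4-fluorophenyl gives a number 11 percentage points lower from compound 2 to compound 4 (beyond the scatter) in this assay, the first single-place reading of fluoro in place of hydrogen on an aromatic carbon. With the fluoro group held constant, methyl in place of hydrogen on an oxygen on an aromatic ring gives a number 17 percentage points lower from compound 1 to compound 4 (beyond the scatter), so each of the two changes registers alone, although compound 1 and compound 2, which differ in more than one place, lie within the scatter of each other. No measurement at hand accounts for either step.

Still open, as far as these compounds go, is whether chloro, an amine or a carboxylic acid in place of the fluoro group would give a step of like size. Also open, from the compounds shown here alone, is whether the fluoro step carries over to the core of compound 3.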